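A Second Methyl Ether and Its Expected Effect

A few compounds are considered here, and "the series" means these few. Any claim that something is new, unique, unknown or untested is made for them only; others in the source may bear on it.

Of the compounds shown here, three have so far been measured in a functional assay on MDA-MB-231 cells (Homo sapiens) for inhibition, read by MTT assay, with a stated time of 72 h; on this read-out lower numbers stand for stronger inhibition and higher numbers for weaker inhibition. Compound 1 `CO[C@@H]1[C@H]2OC(=O)C[C@H]2O[C@@H]1[C@@H](O)c1ccccc1` gives 35200 nM in this assay. Compound 2 `O=C1C[C@H]2O[C@H]([C@H](O)c3ccccc3)[C@H](O)[C@H]2O1` carries a free hydroxy group where compound 1 has a methoxy. In this assay compound 2 gives 75300 nM. Compound 3 `CO[C@@H]1[C@H]2OC(=O)C[C@H]2O[C@@H]1[C@H](O)c1ccccc1` gives 28600 nM in this assay, the lowest of the three numbers. One step is a 1.2-fold lower number from compound 1 to compound 3 (0.09 log units; within the scatter), a difference that arises only from the fact that compounds 1 and 3 differ only in the configuration as drawn and that stays within the scatter, so the two cannot be ordered. The other is a 2.6-fold lower number from compound 2 to compound 3 (0.42 log units; beyond the scatter), a modest step beyond the scatter.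

Compound 4 `CO[C@@H]1[C@H]2OC(=O)C[C@H]2O[C@@H]1[C@H](OC)c1ccccc1` has not yet been measured. It differs from compound 3 in one place: methyl in place of hydrogen on an oxygen on a saturated carbon. Among the compounds with values here, the one measured step that bears on this change is the same kind of methylation at another oxygen, from compound 2 to compound 3, which gave a modest lowering of the number in this assay. On that basis a further lowering is expected for compound 4, but of a smaller or at most similar size, giving an expected step of a 1.6-fold lower number from compound 3 to compound 4 (0.20 log units; within the scatter). Compound 4 is therefore estimated at 18000 nM in this assay, with a range from 8000 nM to 40000 nM.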

Compound 4, half-maximal inhibitory concentration: 1360 nM
Estimate against measurement, compound 4: 13-fold (1.12 log units) above; measured number outside the range, below it.
By their numbers in this assay, from the lowest: compound 4; then compounds 3 and 1 (each within the scatter of the next); then compound 2.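

The change from hydroxy to methoxy on this oxygen is the same one that gave a 2.6-fold lower number from compound 2 to compound 3 (0.42 log units; beyond the scatter) at the other oxygen, yet here in this assay it gives a 21-fold lower number from compound 3 to compound 4 (1.32 log units; beyond the scatter), so the same methylation does not count equally at the two places. Within the data shown here, until now this position had been seen only with its free hydroxy, where the configuration as drawn gave a step that stays within the scatter, a 1.2-fold lower number from compound 1 to compound 3 (0.09 log units; within the scatter), and so these compounds gave no sign that this position could matter so much. Nothing shown here gives a cause for the size of the new step, since the only fact at hand concerns configuration and not this methyl.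

The compounds shown leave open whether the large step needs the methoxy already present at the other oxygen, and whether the configuration at this carbon still makes no readable difference once its oxygen carries a methyl. They also leave open how far the effect extends beyond methyl, for instance to a longer chain such as ethyl on this oxygen, to an acetyl ester, or to an amine in place of the methoxy.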